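From diethylamino to dimethylamino in the series

The source may hold more compounds than are shown below. What is called first, only, known or untested is meant among the compounds shown, and "the series" means these compounds.

In a functional assay on ECa-109 cells (Homo sapiens) for antiproliferative activity, with a stated time of 72 h (on this read-out lower numbers stand for stronger inhibition and higher numbers for weaker inhibition), compound 2 (`CCN(CC)Cc1c(OC)cc(OC)c(C(=O)/C=C/c2ccccc2Cl)c1O`) reads 7100 nM and compound 1 (`COC(=O)CN(C)Cc1c(OC)cc(OC)c(C(=O)/C=C/c2ccccc2Cl)c1O`) reads 13900 nM within the scatter of each other. Compound 3 (`COc1cc(OC)c(C(=O)/C=C/c2ccccc2Cl)c(O)c1CN(C)C`) changes one group, dimethylamino in place of diethylamino on a saturated chain carbon bound to an aromatic carbon. Going by the values given here, the only measured step bearing on this, a 2.0-fold lower number from compound 1 to compound 2 (0.29 log units; within the scatter) (also an amino group exchange at that place), stayed within the scatter, so no step beyond the scatter is expected. In this assay the expected step is a 1.3-fold higher number from compound 2 to compound 3 (0.10 log units; within the scatter) with no firm direction. Compound 3 is estimated at 9000 nM (range 3500 nM to 22000 nM).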

Compound 3, half-maximal inhibitory concentration: 2600 nM
Estimate against measurement, compound 3: 3.5-fold (0.54 log units) above; the measured number lies below the stated range.
By their numbers in this assay, from the lowest: compound 3; then compounds 2 and 1 (each within the scatter of the next).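

In this assay, the amino group on the saturated chain carbon bound to an aromatic carbon now gives a step beyond the scatter, with a 2.7-fold lower number from compound 2 to compound 3 (0.44 log units; beyond the scatter) for dimethylamino in place of diethylamino. The wider exchange, hydrogen in place of methoxycarbonyl on a saturated chain carbon bound to an amine nitrogen, gives a 5.3-fold lower number from compound 1 to compound 3 (0.73 log units; beyond the scatter) and so extends what the earlier pair, within the scatter, could not show. No evidence on the cause of either step is available. Open, going by these compounds, is how a primary amine, a pyrrolidine or a piperidine in this place would read.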